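Series notes: saturating the linker and swapping ester for amide

A few compounds are considered here, and "the series" means these few. Any claim that something is new, unique, unknown or untested is made for them only; others in the source may bear on it.

Compound 3 `CCOC(=O)/C=C/c1ccncc1-c1ccc2ccccc2c1` is the reference here. In an assay on a protein complex for inhibition of CDK8/Cyclin C (Homo sapiens), with a stated time of 1 h (on this read-out lower numbers stand for stronger inhibition and higher numbers for weaker inhibition), compound 3 gives 53.3 nM, the higher of the two numbers in hand; compound 1 `CN1CCN(C(=O)/C=C/c2ccncc2-c2ccc3ccccc3c2)CC1` gives 43.6 nM, and the step of a 1.2-fold higher number from compound 1 to compound 3 (0.09 log units; within the scatter) lies within the scatter. Compound 2 `O=C(O)[C@@H]1CCCN1C(=O)/C=C/c1ccncc1-c1ccc2ccccc2c1` has no result in this assay ("not determined" (no result reported)).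

Compound 4 `CNC(=O)CCc1ccncc1-c1ccc2ccccc2c1` differs from compound 3 by 2-(methylcarbamoyl)ethyl in place of 2-(ethoxycarbonyl)ethenyl on an aromatic carbon. Within the data shown here, the only measured step, from compound 1 to compound 3, exchanges the group on the carbonyl carbon and keeps the ethenyl link; it shows that the carbonyl substituent alone barely moves this assay (a 1.2-fold higher number from compound 1 to compound 3 (0.09 log units; within the scatter)). Among the measured compounds shown here, the change to compound 4 goes further, removing the double bond of the link and turning the ester into an amide, so no measured step covers it. From the compounds shown here alone, the amide part is expected to matter little, the saturation is untested; a moderate weakening is expected, a 2.8-fold higher number from compound 3 to compound 4 (0.45 log units; beyond the scatter), though a result within the scatter cannot be excluded. Compound 4 is estimated at 150 nM, with a range from 40 nM to 600 nM.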

Compound 4, half-maximal inhibitory concentration: 21.1 nM
The estimate for compound 4 lay 7.1-fold (0.85 log units) above the measured number; measured number outside the range, below it.
By their numbers in this assay, from the lowest: compound 4; then compounds 1 and 3 (each within the scatter of the next).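

Neither the double bond of the link nor the ester is required at this aromatic carbon opposite the ring nitrogen for inhibition in this assay (a 2.5-fold lower number from compound 3 to compound 4 (0.40 log units; beyond the scatter)), since 2-(methylcarbamoyl)ethyl gives the lower number in place of 2-(ethoxycarbonyl)ethenyl. The exchange on the carbonyl carbon with the ethenyl link kept stayed within the scatter (a 1.2-fold higher number from compound 1 to compound 3 (0.09 log units; within the scatter)), whereas this combined change of link and carbonyl group lies beyond it, so the substituent here can move this read-out, though only modestly. No measurement in hand gives a reason for the shift.

From the compounds shown here alone, how the step divides between saturating the link and exchanging ester for amide remains open. Also open, going by these compounds, is how a longer alkyl chain carrying the methylcarbamoyl group, or a primary amide on the same ethyl link, would read in this assay on this core.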